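Benzyl to Aryl Amide Swap at the Assay Limit

The source may report more compounds than this note shows. Statements on the series, on what has been measured and on what is new or still open speak of the compounds shown alone.

compound 1 `COc1ccc2c(=O)c(/C=C/C(=O)NCc3cccc(F)c3)coc2c1`: > 200000 nM
compound 2 `COc1ccc2c(=O)c(/C=C/C(=O)NCc3ccccc3F)coc2c1`: > 200000 nM

Compound 1 `COc1ccc2c(=O)c(/C=C/C(=O)NCc3cccc(F)c3)coc2c1` and compound 2 `COc1ccc2c(=O)c(/C=C/C(=O)NCc3ccccc3F)coc2c1` share one core and differ only in where the fluorine sits on the ring bound to the amide nitrogen through a saturated carbon. In a functional assay on L02 cells (Homo sapiens) for inhibition, read by MTT assay, with a stated time of 48 h (on this read-out higher numbers stand for weaker inhibition and lower numbers for stronger inhibition), compound 1 gives > 200000 nM, which is a limit of the assay and not a number. Compound 2 also reaches only a limit in this assay, > 200000 nM. The step that the two limits leave unreadable from compound 1 to compound 2 is therefore unreadable, as the limit of > 200000 nM in this assay, at which 2 of the 2 values shown sit, shows. Compound 2 thus stands at the limit, without a measured number.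

Compound 3 `COc1ccc2c(=O)c(/C=C/C(=O)Nc3ccccc3C)coc2c1` differs from compound 2 by 2-methylphenyl in place of 2-fluorobenzyl on an amide-type nitrogen. Among the compounds with values here, no measured step bears on this change, since the only step available is unreadable; no size or direction can be drawn from the data. The expected step is a number no higher from compound 2 to compound 3 (the limit leaves the size open), meaning compound 3 is estimated to stay near the limit. Compound 3 is expected to give 200000 nM, between 40000 nM and 1000000 nM, most likely again reported only as a limit.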

Compound 3, half-maximal inhibitory concentration: > 200000 nM
Compound 3 gave a limit, no number; the forecaster's own chance of this, stated with the estimate: 80%; the middle value lies on the limit itself.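

Compound 3 gives only a limit of the assay and not a number, so no step among compound 1, compound 2 and compound 3 can be read in this assay: the limit of > 200000 nM in this assay, at which 3 of the 3 values shown sit.

Going by these compounds, whether moving the fluorine, or placing 2-methylphenyl on the amide-type nitrogen, changes inhibition at all stays open.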